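Cytotoxicity notes: from compound 2 to compound 4

A few compounds are considered here, and "the series" means these few. Any claim that something is new, unique, unknown or untested is made for them only; others in the source may bear on it.

Measured so far in an ADME assay on MRC5 cells (Homo sapiens) for cytotoxicity, read by MTT assay, with a stated time of 96 h; a lower number here means that less compound is needed, a higher number that more compound is needed for the effect:
- compound 1 `CC(=O)/C(=C/c1c(-c2ccccc2)[nH]c2ccccc12)C(=O)c1ccccc1`: > 100000 nM, a limit of the assay
- compound 2 `CCOC(=O)/C(=C/c1c(-c2ccccc2)[nH]c2ccccc12)C(=O)c1ccc([N+](=O)[O-])cc1`: > 100000 nM, a limit of the assay
- compound 3 `O=C(/C(=C\c1c(-c2ccccc2)[nH]c2ccccc12)C(=O)C(F)(F)F)c1ccco1`: 12000 nM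

Compound 2 stands at the upper limit of this assay, and its value is not a number. Compound 1 sits at the same limit, which is the limit of > 100000 nM in this assay, at which 2 of the 3 values shown sit. Among the compounds with values here, only compound 3 gives a number, and since no pair of these three differs in a single place, no step between measured compounds can be read off.

Compound 4 `CCOC(=O)/C(=C/c1c(-c2ccccc2)[nH]c2ccccc12)C(=O)c1ccccc1` is the next one to go into this assay. It differs from compound 2 by hydrogen in place of nitro on an aromatic carbon, in words: hydrogen in place of nitro on an aromatic carbon.

Nothing measured constrains this step directly. The step of a number no higher from compound 2 to compound 4 (the limit leaves the size open) is expected to be none beyond the scatter, because compound 1, which also carries a benzoyl without a nitro, sits at > 100000 nM. Compound 4 is estimated at 100000 nM, between 30000 nM and 300000 nM, most likely reported again only as a limit.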

Compound 4, half-maximal effective concentration: > 100000 nM
Compound 4 gave a limit, no number; the forecaster's own chance of this, stated with the estimate: 65%; the middle value sits exactly at the limit.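

Compound 4 gives > 100000 nM as a limit of the assay, not a number. No step can be read from compound 2 or compound 1 to compound 4, as all three sit at one limit: the limit of > 100000 nM in this assay, at which 3 of the 4 values shown sit.

The compounds shown leave open whether hydrogen in place of nitro, or ethoxy in place of methyl, changes the value at all.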